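This account rests on a few compounds, and the source may have more. Where it says the series, first, only, none or still open, it means among the compounds named here.

In a functional assay on HeLa cells (Homo sapiens) for antiproliferative activity, read by CCK-8 assay, with a stated time of 72 h (on this read-out lower numbers stand for stronger inhibition and higher numbers for weaker inhibition), compound 1 (`Nc1ccccc1NC(=O)c1ccc(CSc2cccc(F)c2)cc1`) gives 3240 nM and so holds the lower of the two numbers available, while compound 2 (`COC(=O)c1ccccc1SCc1ccc(C(=O)Nc2ccccc2N)cc1`) gives 6680 nM and lies just beyond the usual scatter from it. Compound 3 (`Nc1ccccc1NC(=O)c1ccc(CSc2ccc(Cl)cc2)cc1`) keeps the core of compound 1 and carries 4-chlorophenyl in place of 3-fluorophenyl on a sulfur. Within the data shown here, no measured pair differs in one place only, so the data offer no direct precedent for this exchange, and the expectation starts from the value of compound 1 (3240 nM). The expected step (a 1.1-fold lower number from compound 1 to compound 3 (0.03 log units; within the scatter)) is small, with no shift in either direction beyond the scatter in this assay anticipated. The estimated value for compound 3 is 3000 nM (expected range 1200 nM to 7500 nM).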

Compound 3, half-maximal inhibitory concentration: 12700 nM
Compound 3: the middle estimate sits 4.2-fold (0.63 log units) below what was measured; the measured number lies above the stated range.
By their numbers in this assay, from the lowest: compound 1; then compounds 2 and 3 (each within the scatter of the next).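

In this assay, among these compounds, putting 4-chlorophenyl in place of 3-fluorophenyl on a sulfur gives a 3.9-fold higher number from compound 1 to compound 3 (0.59 log units; beyond the scatter) and is the only single-place step available here. The two groups have the same heavy-atom count and the same count of hydrogen-bond donors and acceptors, yet the step lies beyond the scatter, so those counts alone do not settle the read-out at this position. No measurement at hand accounts for the rise.

The exchange alters both the halogen and its location at once, so the compounds shown cannot assign the step to either change; 3-chlorophenyl or 4-fluorophenyl would separate the two. As far as these compounds go, it also remains open how unsubstituted phenyl, or a group such as 4-methoxyphenyl, would read at this sulfur.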